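A few compounds are considered here, and "the series" means these few. Any claim that something is new, unique, unknown or untested is made for them only; others in the source may bear on it.

Measured compounds in a functional assay on MCF7 cells (Homo sapiens) for cytotoxicity, read by MTT assay, with a stated time of 4 days; a lower number here means a stronger inhibitor, a higher number a weaker inhibitor:
- compound 1, `C=C1C[C@]23C[C@@]1(O)CC[C@@H]2c1cccc(C)c1[C@@H]3Cn1cc(-c2ccc(Br)cc2)nn1`; in this assay compound 1 gives > 20000 nM, which is a limit of the assay and not a number.
- compound 2, `C=C1C[C@]23C[C@@]1(O)CC[C@H]2c1cc(Br)c(O)c(C)c1[C@@H]3Cn1cc(-c2ccc(C)cc2)nn1`; in this assay compound 2 gives > 20000 nM, again a limit rather than a number.

Compound 1 therefore stands at the top limit of the measured range, and no measured number exists beside it. Among the compounds with values here, the only other measured compound, compound 2, also stops at a limit, so no step between measured compounds is available and nothing so far shows a change that moves the read-out.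

The next compound, compound 3, `C=C1C[C@]23C[C@@]1(O)CC[C@@H]2c1cccc(C)c1[C@@H]3Cn1cc(-c2ccc(Cl)cc2)nn1`, differs from compound 1 in one place: chloro in place of bromo on an aromatic carbon. Within the data shown here, no measured step of this kind exists, so the size of the step has to be judged from the standing of compound 1 alone. Given (the limit of > 20000 nM in this assay, at which 2 of the 2 values shown sit), the expectation is that compound 3 stays where compound 1 sits, with no step beyond the scatter in either direction.

For compound 3 the estimated value in this assay is 25000 nM, within a range of 10000 nM to 60000 nM, which corresponds to an expected step that the limit leaves unreadable from compound 1 to compound 3.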

Compound 3, half-maximal inhibitory concentration: > 20000 nM
Compound 3 ended at the assay's limit; the forecaster's own chance of this, stated with the estimate: 80%; the middle value lies beyond the limit too.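

In this assay compound 3 gives > 20000 nM, a limit of the assay and not a number. Compound 1 also stops at a limit, so the step for chloro in place of bromo between compound 1 and compound 3 cannot be read. The compounds shown leave open which change, if any, would bring a measured number in this assay.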